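This account rests on a few compounds, and the source may have more. Where it says the series, first, only, none or still open, it means among the compounds named here.

Measured compounds:
Compound 1, `COc1cc(OC)cc(N2NC3=CC[C@@H](OC)O[C@@]3(c3ccccc3)CC2=O)c1`, gives 17300 nM in a functional assay on A549 cells (Homo sapiens) for inhibition, read by sulforhodamine B assay, with a stated time of 48 h; on this read-out lower numbers stand for stronger inhibition and higher numbers for weaker inhibition.
Compound 2, `COc1cc(OC)cc(N2NC3=CC[C@@H](OC)O[C@@]3(C)CC2=O)c1`, gives 6150 nM in this assay.
Compound 3, `CO[C@@H]1CC=C2NN(c3cncnc3)C(=O)C[C@]2(C)O1`, gives 4100 nM in this assay.

Compound 3 stands lowest of the three, though its gap to compound 2 lies within the scatter; only compound 1 sits beyond it. The difference between the cores of compound 2 and compound 3 is not broken down here. Between compound 2 and compound 1 the change is phenyl in place of methyl on a saturated ring carbon, and it brought a 2.8-fold higher number from compound 2 to compound 1 (0.45 log units; beyond the scatter). Compound 4, `CO[C@@H]1CC=C2NN(c3cncnc3)C(=O)C[C@]2(c2ccccc2)O1`, is not yet measured; it carries the same kind of change relative to compound 3, (phenyl in place of methyl on a saturated ring carbon), although its place line reads as a ring with one oxygen rather than two nitrogens. Because compound 2 to compound 1 showed a 2.8-fold higher number from compound 2 to compound 1 (0.45 log units; beyond the scatter), compound 4 is expected to show a 2.7-fold higher number from compound 3 to compound 4 (0.43 log units; beyond the scatter), a similar weakening. The estimated value of compound 4 in this assay is 11000 nM, likely between 5000 nM and 25000 nM.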

Compound 4, half-maximal inhibitory concentration: 5200 nM
Compound 4: middle estimate off by 2.1-fold (0.33 log units), on the high side; low and high end bracket the measured number.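

On the second core, phenyl in place of methyl on a saturated ring carbon gave a 1.3-fold higher number from compound 3 to compound 4 (0.10 log units; within the scatter) in this assay, so this step, unlike the earlier one, does not stand clear of the scatter. Set side by side, the two steps cannot be told apart: the same change on two cores in this assay, a 2.8-fold higher number (0.45 log units; beyond the scatter) from compound 2 to compound 1 and a 1.3-fold higher number (0.10 log units; within the scatter) from compound 3 to compound 4, 2.2-fold (0.35 log units) apart, within the scatter of two such steps. This fits a change that carries across both cores, but it does not show that the size of the effect is the same on each, nor that it depends on the core.

The compounds shown carry only methyl or phenyl at this ring carbon, so the outcome with a longer chain, a benzyl group or an amine there remains open. Going by these compounds, they also span a single cell line, so whether these steps hold in other cells is equally open.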